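This account rests on a few compounds, and the source may have more. Where it says the series, first, only, none or still open, it means among the compounds named here.

Measured so far:
Compound 1 `CC(=O)O[C@@H]1[C@@H](OC(C)=O)[C@@H](O)[C@@H](CO)O[C@H]1NC(=S)NNC(=O)Cn1cnc2ccccc21`. In a functional assay on PG cells (Homo sapiens) for cytotoxicity, read by MTT assay, with a stated time of 48 h (on this read-out higher numbers stand for an effect only at larger amounts of compound and lower numbers for an effect already at smaller amounts), compound 1 gives only a limit, > 100000 nM.
Compound 2 `CC(=O)O[C@@H]1[C@@H](OC(C)=O)[C@@H](O)CO[C@H]1NC(=S)NNC(=O)Cn1cnc2ccccc21`. In this assay compound 2 gives only a limit, > 200000 nM.
Compound 3 `COc1ccc(C(=O)Nc2nc3ccccc3n2CC(=O)NNC(=S)N[C@@H]2O[C@H](CO)[C@H](O)[C@H](OC(C)=O)[C@H]2OC(C)=O)cc1`. In this assay, among the measured compounds shown here, compound 3 gives 82400 nM, the one number among the three.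

Compound 1 and compound 2 differ by hydrogen in place of hydroxymethyl on a saturated ring carbon; the two limits leave the step that the two limits leave unreadable from compound 1 to compound 2. The cores of compound 1 and compound 3 differ by ((4-methoxyphenyl)carbonyl)amino in place of hydrogen on an aromatic carbon, a step of an at least 1.2-fold lower number from compound 1 to compound 3 (0.08 log units; that floor lies within the scatter). Compound 4 `COc1ccc(C(=O)Nc2nc3ccccc3n2CC(=O)NNC(=S)N[C@@H]2OC[C@H](O)[C@H](OC(C)=O)[C@H]2OC(C)=O)cc1` is not yet measured; from compound 3 it differs by hydrogen in place of hydroxymethyl on a saturated ring carbon, the same change as from compound 1 to compound 2. The expectation for compound 4 rests on compound 3 at 82400 nM and on the unreadable step that the two limits leave unreadable from compound 1 to compound 2, which gives no size. Compound 4 is expected in this assay to give about 120000 nM, within 50000 nM and 300000 nM, an expected step of a 1.5-fold higher number from compound 3 to compound 4 (0.16 log units; within the scatter). A limit rather than a number is a real possibility.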

Compound 4, half-maximal effective concentration: 73700 nM
The estimate for compound 4 lay 1.6-fold (0.21 log units) above the measured number, and the stated range covers the measured number.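

In this assay, hydrogen in place of hydroxymethyl on a saturated ring carbon gives a 1.1-fold lower number from compound 3 to compound 4 (0.05 log units; within the scatter) on the core of compound 3. The same change cannot be read between compound 1 and compound 2, so these compounds do not show that its size carries from one core to the other. The change on the aromatic carbon gives an at least 2.7-fold lower number from compound 2 to compound 4 (0.43 log units; beyond the scatter) in this assay, and beside the earlier step the comparison stays unresolved: the same change on two cores in this assay, an at least 1.2-fold lower number (0.08 log units; that floor lies within the scatter) from compound 1 to compound 3 and an at least 2.7-fold lower number (0.43 log units; beyond the scatter) from compound 2 to compound 4; the limit leaves it open whether they differ.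

Still open, on these data alone, is what an amine or a carboxylic acid would give on that saturated ring carbon. Also open, as far as these compounds go, is whether a longer chain in place of ((4-methoxyphenyl)carbonyl)amino would give a clearly different number.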